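This account rests on a few compounds, and the source may have more. Where it says the series, first, only, none or still open, it means among the compounds named here.

Compound 1, `O=C1/C(=C\c2ccccc2)C(c2ccccc2)Oc2ccccc21`, gives only a limit in a functional assay on NALM-6 cells (Homo sapiens) for cytotoxicity, read by MTT assay, with a stated time of 46 h; a higher number here means a weaker inhibitor, a lower number a stronger inhibitor: > 1000000 nM.
Compound 2, `O=C1/C(=C/c2ccccc2)C(c2ccccc2)Oc2ccccc21`, gives 29500 nM in this assay.
Compound 3, `O=C1/C(=C\c2ccccc2)C(c2ccccc2)Oc2ccc(O)cc21`, gives 58800 nM in this assay.

Compound 1 therefore stands at the edge of what this assay can report, the weakest position on the numbers shown, as the limit of > 1000000 nM in this assay, at which 1 of the 3 values shown sits, makes plain. The change to compound 4, `O=C1/C(=C\c2ccc(Cl)cc2)C(c2ccccc2)Oc2ccccc21`, is chloro in place of hydrogen on an aromatic carbon.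

Two measured steps start from compound 1. The step of an at least 33-fold lower number from compound 1 to compound 2 (1.53 log units; beyond the scatter) rests on (the fact that one of compounds 1 and 2 is drawn with a defined configuration and the other without, at the place where they differ), a difference in how the double bond is drawn, not on any group added to a ring. The step of an at least 17-fold lower number from compound 1 to compound 3 (1.23 log units; beyond the scatter) adds a hydroxy group to the fused ring of the core. Neither step touches the phenyl that carries the new chloro in compound 4, so neither bears directly on it; both only show that a single change from compound 1 can move the number a long way.

Among the measured compounds shown here, with no step touching that phenyl, the expectation for compound 4 is a number close to the limit of compound 1, a step that the limit leaves unreadable from compound 1 to compound 4, and a good chance that this assay again reports only a limit. The estimate for compound 4 is 1500000 nM, expected to fall between 300000 nM and 10000000 nM.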

Compound 4, half-maximal inhibitory concentration: > 1000000 nM
Compound 4: only a limit was reported; the forecaster's own chance of this, stated with the estimate: 65%; the middle value does not contradict the limit.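

In this assay, among the compounds shown here, compound 1 and compound 4 each give only a limit, not a number, so the step between them cannot be read and no new step follows. The compounds shown leave open whether 4-chlorophenyl in place of phenyl changes the number at all, on this core or on one with a measurable value.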